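This account rests on a few compounds, and the source may have more. Where it says the series, first, only, none or still open, it means among the compounds named here.

Measured so far:
compound 1 `Oc1ccccc1CNc1ccc(-c2ccc(Cl)cc2)cc1` — 2390 nM
compound 2 `COc1ccc(-c2ccc(NCc3ccccc3O)cc2)cc1` — 580 nM

Both were tested in a functional assay on Jurkat cells (Homo sapiens) for activation, with a stated time of 24 h; a lower number here means that less compound is needed, a higher number that more compound is needed for the effect. Compound 2 stands at the lowest number of the two, with compound 1 next at a 4.1-fold lower number from compound 1 to compound 2 (0.61 log units; beyond the scatter). Compound 3 `CCSc1ccc(-c2ccc(NCc3ccccc3O)cc2)cc1` differs from compound 2 by ethylsulfanyl in place of methoxy on an aromatic carbon. Among the compounds with values here, no measured step changes one group on that carbon for another of this kind; the only step seen is a chloro replaced by methoxy, and that was modest. Compound 3 is therefore expected to stay close to compound 2, with a 1.1-fold higher number from compound 2 to compound 3 (0.05 log units; within the scatter) meaning a change within the scatter or slightly beyond it. The estimate for compound 3 is 650 nM, between 200 nM and 2100 nM.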

Compound 3, half-maximal effective concentration: 1980 nM
The estimate for compound 3 lay 3.0-fold (0.48 log units) below the measured number; the measured number falls inside the stated range.
By their numbers in this assay, from the lowest: compound 2; then compounds 3 and 1 (each within the scatter of the next).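

Changing the group on this aromatic carbon matters in this assay: ethylsulfanyl in place of methoxy gives a 3.4-fold higher number from compound 2 to compound 3 (0.53 log units; beyond the scatter), even though both groups count one hydrogen-bond acceptor. Ethylsulfanyl in place of chloro gives a 1.2-fold lower number from compound 1 to compound 3 (0.08 log units; within the scatter), so among these three compounds only the methoxy of compound 2 stands apart. No measurement shown here explains this difference.

Still open, on these data alone, is how ethoxy or methylsulfanyl on this carbon would compare with compound 2. Those two groups could help separate the effect of the sulfur from that of the longer chain.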